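This account rests on a few compounds, and the source may have more. Where it says the series, first, only, none or still open, it means among the compounds named here.

Measured in a functional assay on Jurkat cells (Homo sapiens); on this read-out lower numbers stand for stronger inhibition and higher numbers for weaker inhibition:
- compound 1 `Cc1ccccc1CNC(=O)C(=O)N[C@@H](C)C(=O)N[C@@H](CC(=O)O)C(=O)COc1c(F)c(F)cc(F)c1F`: 52 nM
- compound 2 `Cc1cccc(CNC(=O)C(=O)N[C@@H](C)C(=O)N[C@@H](CC(=O)O)C(=O)COc2c(F)c(F)cc(F)c2F)c1C`: 102 nM

For the measured compounds named here, of the two compounds measured so far, compound 2 stands within the scatter of compound 1. Compound 3 `Cc1ccc(CNC(=O)C(=O)N[C@@H](C)C(=O)N[C@@H](CC(=O)O)C(=O)COc2c(F)c(F)cc(F)c2F)c(C)c1` has not yet been measured. It carries 2,4-dimethylphenyl in place of 2,3-dimethylphenyl on a saturated chain carbon bound to an amide-type nitrogen. The same atoms are simply joined differently. Going by the values given here, only one measured step bears on this change: a 2.0-fold higher number from compound 1 to compound 2 (0.29 log units; within the scatter), which puts methyl in place of hydrogen on an aromatic carbon. That step did not leave the scatter, so no step beyond the scatter is expected in this assay, and no direction can be expected with confidence. The expected change is a 1.2-fold lower number from compound 2 to compound 3 (0.08 log units; within the scatter). The estimate for compound 3 is 85 nM, with an expected range from 30 nM to 240 nM.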

Compound 3, half-maximal inhibitory concentration: > 10000 nM
Compound 3: a limit, no number; the forecaster's own chance of this, stated with the estimate: 2%; middle value at least 110-fold (2.07 log units) from the limit.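

In this assay compound 3 gives > 10000 nM, a limit of the assay and not a number. Exchanging 2,3-dimethylphenyl for 2,4-dimethylphenyl, with the same atoms joined differently, gives an at least 98-fold higher number from compound 2 to compound 3 (1.99 log units; beyond the scatter), and the comparison with the compound lacking the second methyl gives an at least 190-fold higher number from compound 1 to compound 3 (2.28 log units; beyond the scatter). The earlier step stayed within the scatter and suggested that a second methyl made little difference, whereas compound 3 shows that in this series the arrangement of the methyl groups on the phenyl ring, and not only their presence, governs the read-out.

As far as these compounds go, whether a phenyl ring carrying methoxy or chlorine in place of the methyl groups of 2,4-dimethylphenyl would behave the same stays open. How far compound 3 lies past this value also stays unknown: the limit of > 10000 nM in this assay, at which 1 of the 3 values shown sits.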